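The compounds below may be only part of what the source reports. "The series", "measured", "known", "first", "only" and "open" are said of these compounds alone.

Measured so far:
compound 1 `COc1ccc(N2C(=O)COc3ccc(-c4cnc(OC)c(NS(=O)(=O)c5ccc(F)cc5)c4)cc32)cc1` — 13100 nM
compound 2 `O=C1COc2ccc(-c3cnc(Cl)c(NS(=O)(=O)c4ccc(F)cc4)c3)cc2N1c1ccccc1` — 35700 nM
compound 3 `O=C1COc2ccc(-c3ccc(O)cc3)cc2N1` — 38200 nM

All three compounds were tested in a functional assay on HepG2 cells (Homo sapiens) for antiproliferative activity, read by MTT assay, with a stated time of 72 h; a lower number here means a stronger inhibitor, a higher number a weaker inhibitor. Among the three numbers, compound 2 at 35700 nM has the second highest value. Compound 3 gives 38200 nM, which lies within the scatter of the value of compound 2, so the two cannot be told apart. Compound 1 gives 13100 nM, a lower number beyond the scatter, so compound 1 is a stronger inhibitor than compound 2.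

Compound 4 `O=C1COc2ccc(-c3cnc(Cl)c(NS(=O)(=O)c4ccc(F)cc4)c3)cc2N1` has not yet been measured. It differs from compound 2 in one place: hydrogen in place of phenyl on an amide-type nitrogen in a ring. Among the measured compounds shown here, no pair of measured compounds shows this change on its own, so there is no measured step to lean on. For the measured compounds named here, compound 3 carries hydrogen at the same nitrogen, but it also differs from compound 2 elsewhere, so its value shows only that a compound with hydrogen there can sit near compound 2 in this assay. The expectation is therefore a step that stays within the scatter or drifts slightly toward a higher number, estimated as a 1.2-fold higher number from compound 2 to compound 4 (0.07 log units; within the scatter). Compound 4 is expected to give 42000 nM, with a range from 15000 nM to 110000 nM.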

Compound 4, half-maximal inhibitory concentration: > 40000 nM
Compound 4: no number, only a limit; the forecaster's own chance of this, stated with the estimate: 20%; the middle value lies beyond the limit too.
By their numbers in this assay, from the lowest: compound 1; then compounds 2 and 3 (each within the scatter of the next). At a limit, above all of these: compound 4.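

In this assay, compound 4 has no number, only a limit: > 40000 nM. Among the compounds shown here, putting hydrogen in place of phenyl on the amide-type nitrogen now gives the first direct reading of this change on its own: an at least 1.1-fold higher number from compound 2 to compound 4 (0.04 log units; that floor lies within the scatter). Hydrogen at this position gives no sign of a stronger inhibitor, but whether it gives a weaker one stays unsettled, and the size of the step remains open upward, with only a limit to go on: the limit of > 40000 nM in this assay, at which 1 of the 4 values shown sits.

The compounds shown leave open how a small carbon group such as methyl, a benzyl group, or a longer chain ending in an amine would behave on this same nitrogen. They also leave open whether hydrogen in place of phenyl would read the same way on the core of compound 1, which carries other groups elsewhere.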